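Methoxycarbonyl in place of methoxy: compound 3 to compound 4

This account rests on a few compounds, and the source may have more. Where it says the series, first, only, none or still open, it means among the compounds named here.

compound 1 `C=c1[nH]c(=O)/c(=C/c2ccccc2)[nH]c1=O`: > 20000 nM
compound 2 `C=c1[nH]c(=O)/c(=C/c2ccc(C)cc2)[nH]c1=O`: > 20000 nM
compound 3 `C=c1[nH]c(=O)/c(=C/c2ccc(OC)cc2)[nH]c1=O`: > 20000 nM

In a functional assay on Huh7.5.1 cells (Homo sapiens) for cytotoxicity, read by MTT assay, with a stated time of 72 h (a higher number here means that more compound is tolerated, a lower number that less compound is tolerated), compound 3 stands at > 20000 nM, which is a limit of the assay and not a number. It shares this position with the other two measured compounds, as the evidence shows: the limit of > 20000 nM in this assay, at which 3 of the 3 values shown sit.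

Compound 4 `C=c1[nH]c(=O)/c(=C/c2ccc(C(=O)OC)cc2)[nH]c1=O` carries methoxycarbonyl in place of methoxy on an aromatic carbon of the same six-membered ring, para to a large group: methoxycarbonyl in place of methoxy on an aromatic carbon.

Within the data shown here, three measured steps bear on this change: a step that the two limits leave unreadable from compound 1 to compound 3, a step that the two limits leave unreadable from compound 2 to compound 3 and a step that the two limits leave unreadable from compound 1 to compound 2. Each is a change at the same kind of aromatic carbon, yet none gives a readable size. They offer no sign of a change in either direction, so no step beyond the scatter is expected in this assay.

The step is expected to be a step that the limit leaves unreadable from compound 3 to compound 4. Compound 4 is estimated at 30000 nM, with an expected range from 14000 nM to 60000 nM.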

Compound 4, half-maximal cytotoxic concentration: > 20000 nM
Compound 4 ended at the assay's limit; the forecaster's own chance of this, stated with the estimate: 85%; the middle value does not contradict the limit.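

In this assay compound 4 gives > 20000 nM, a limit of the assay and not a number, so its steps from compound 1, compound 2 and compound 3 cannot be read. The compounds shown leave open whether any change at this aromatic carbon alters how much compound is tolerated, since all share one position: the limit of > 20000 nM in this assay, at which 4 of the 4 values shown sit.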